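Two weak HSP60/HSP10 inhibitors and a nitrophenyl amide variant

A few compounds are considered here, and "the series" means these few. Any claim that something is new, unique, unknown or untested is made for them only; others in the source may bear on it.

Compound 1 `COc1ccccc1S(=O)(=O)Nc1ccc(-c2nc3cc(NS(=O)(=O)c4ccccc4OC)ccc3o2)cc1`: 87000 nM
Compound 2 `COc1ccc(S(=O)(=O)Nc2ccc3oc(-c4ccc(NC(=O)c5ccc(Cl)s5)cc4)nc3c2)cc1`: 61000 nM

Both compounds were characterised in an assay on mitochondria for inhibition of HSP60/HSP10 (Homo sapiens); a higher number here means a weaker inhibitor, a lower number a stronger inhibitor. Compound 1 gives 87000 nM there, and compound 2 gives 61000 nM. Compound 2 holds the lowest of the two numbers, but the gap to compound 1 lies within the scatter of the measurement, so the two cannot be told apart on these data.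

Compound 3 `COc1ccc(S(=O)(=O)Nc2ccc3oc(-c4ccc(NC(=O)c5cccc(C)c5[N+](=O)[O-])cc4)nc3c2)cc1` remains to be measured. It differs from compound 2 in a single place (3-methyl-2-nitrophenyl in place of 5-chlorothiophen-2-yl on a carbonyl carbon). Among the compounds with values here, no step between measured compounds shows what this exchange of one carbonyl substituent for another does to the read-out, so there is nothing in the measured pair to anchor a direction. Compound 3 is therefore expected to land close to compound 2, with a step of a 1.1-fold higher number from compound 2 to compound 3 (0.06 log units; within the scatter) that stays within the scatter. Taken as an estimate, compound 3 is expected to give about 70000 nM, within a range from 25000 nM to 200000 nM.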

Compound 3, half-maximal inhibitory concentration: 72000 nM
Beside the measured number, compound 3's estimate is 1.0-fold (0.01 log units) below it; measured number inside the range.
By their numbers in this assay, from the lowest: compounds 2, 3 and 1 (each within the scatter of the next).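

In this assay, within the data shown here, placing 3-methyl-2-nitrophenyl in place of 5-chlorothiophen-2-yl on a carbonyl carbon gives a 1.2-fold higher number from compound 2 to compound 3 (0.07 log units; within the scatter) and is the first step that can be read at this position. The position therefore accepts a six-membered aromatic ring of carbon only, carrying methyl and nitro groups, instead of a five-membered aromatic ring with 1 hetero atom, without a change that can be separated from the scatter. Nothing measured on these compounds gives a reason for this result. As far as these compounds go, it remains open whether a group without an aromatic ring on this carbonyl carbon, such as a carboxylic acid, an amine or a longer alkyl chain, would move the read-out beyond the scatter. The compounds shown also leave open whether any change at this position can turn these weak inhibitors into markedly stronger ones.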